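The compounds below may be only part of what the source reports. "The series", "measured", "known", "first", "only" and "open" are said of these compounds alone.

Measured compounds:
compound 1, `Cc1ccc(-c2ccc(C3(C)CC(S(=O)(=O)c4ccc(F)cc4)=C(c4ccc(/C(N)=N\O)cc4)O3)cc2)cc1`: 7910 nM
compound 2, `CC1(Cc2ccccc2)CC(S(=O)(=O)c2ccccc2F)=C(c2ccc(/C(N)=N\O)cc2)O1`: 29100 nM
compound 3, `CC1(Cc2ccccc2)CC(S(=O)(=O)c2cccc(F)c2)=C(c2ccc(/C(N)=N\O)cc2)O1`: 28300 nM

These three compounds were tested in an ADME assay on J774.A1 cells (Mus musculus) for cytotoxicity, read by MTT assay, with a stated time of 72 h; on this read-out lower numbers stand for higher toxicity in this test and higher numbers for lower toxicity in this test. Compound 1 gives the lowest number of the three, so it is the most toxic here: compound 3 sits a 1.0-fold lower number from compound 2 to compound 3 (0.01 log units; within the scatter) and compound 2 is close to compound 3, both well beyond the scatter above compound 1.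

The next compound is compound 4, `COc1cc(-c2ccc(C3(C)CC(S(=O)(=O)c4ccc(F)cc4)=C(c4ccc(/C(N)=N\O)cc4)O3)cc2)cc(OC)c1OC`. It differs from compound 1 in one place: 3,4,5-trimethoxyphenyl in place of 4-methylphenyl on an aromatic carbon. Among the measured compounds shown here, the only measured step, from compound 2 to compound 3, moves a fluorine around the ring on the sulfonyl sulfur and changes nothing beyond the scatter; it does not touch the group that is exchanged here, so no measured step speaks directly to this change. With nothing pointing either way, the expectation is that compound 4 stays near compound 1, a step of a 1.1-fold higher number from compound 1 to compound 4 (0.03 log units; within the scatter), within the scatter. Compound 4 is therefore estimated at 8500 nM, in a range from 3500 nM to 20000 nM.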

Compound 4, half-maximal cytotoxic concentration: 5220 nM
Compound 4: the middle estimate sits 1.6-fold (0.21 log units) above what was measured, and the stated range covers the measured number.
By their numbers in this assay, from the lowest: compounds 4 and 1 (each within the scatter of the next); then compounds 3 and 2 (each within the scatter of the next).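

In this assay, placing 3,4,5-trimethoxyphenyl in place of 4-methylphenyl on an aromatic carbon, para to a large group, gives a 1.5-fold lower number from compound 1 to compound 4 (0.18 log units; within the scatter). This position of the shared core therefore accepts a larger group carrying hydrogen-bond acceptors, where the group it replaces has none, with no change in this test that can be told apart from the scatter. No measurement bears on why the two compounds read alike in this test.

The compounds shown compare only these two aromatic groups at this position, so how an amine or a carboxylic acid on that ring would read remains open. Also open, on these data alone, is whether a longer chain in place of the whole ring would stay in the same range.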